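A few compounds are considered here, and "the series" means these few. Any claim that something is new, unique, unknown or untested is made for them only; others in the source may bear on it.

Compound 3 `CCc1ccc(-c2ccnc(C(=O)Nc3ccc(Oc4ccnc5[nH]ccc45)c(F)c3)c2)cc1` stands among three measured compounds at the second highest number in a functional assay on HeLa cells (Homo sapiens) for cytotoxicity, read by MTT assay, with a stated time of 72 h; a lower number here means a stronger inhibitor, a higher number a weaker inhibitor. In this assay compound 3 gives 8630 nM. Its nearest neighbour is compound 1 `COc1ccc(-c2ccnc(C(=O)Nc3ccc(Oc4ccnc5[nH]ccc45)cc3)c2)cc1`, which in this assay gives 7530 nM, and its furthest is compound 2 `Cc1ccc(-c2ccnc(C(=O)Nc3ccc(Oc4ccnc5[nH]ccc45)c(F)c3)c2)c(C)c1`, which in this assay gives 11900 nM; all three numbers sit within the usual scatter of each other.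

Among the compounds with values here, the only measured step between single-point neighbours is a 1.4-fold lower number from compound 2 to compound 3 (0.14 log units; within the scatter), which exchanged 2,4-dimethylphenyl for 4-ethylphenyl on an aromatic carbon and did not move the number beyond the scatter.

Compound 4 `COc1ccc(-c2ccnc(C(=O)Nc3ccc(Oc4ccnc5[nH]ccc45)c(F)c3)c2)cc1` differs from compound 3 by methoxy in place of ethyl on an aromatic carbon, the same difference, cut one bond further out, reading 4-ethylphenyl to 4-methoxyphenyl, on an aromatic carbon of a six-membered aromatic ring of carbon only, para to a large group. Compound 1 already carries the methoxyphenyl on the same core without the fluorine, and its number lies within the scatter of compound 3. Both the measured step and that comparison point to a change of small size. Compound 4 is therefore expected to show a step of a 1.1-fold lower number from compound 3 to compound 4 (0.03 log units; within the scatter), with no movement beyond the scatter. Compound 4 is estimated at 8000 nM, within a range from 4000 nM to 16000 nM.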

Compound 4, half-maximal inhibitory concentration: 5890 nM
Beside the measured number, compound 4's estimate is 1.4-fold (0.13 log units) above it, and the stated range covers the measured number.
By their numbers in this assay, from the lowest: compounds 4, 1, 3 and 2 (each within the scatter of the next, the first and the last beyond it).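

In this assay, exchanging ethyl for methoxy on the aromatic carbon para to a large group gave a 1.5-fold lower number from compound 3 to compound 4 (0.17 log units; within the scatter), so this exchange of one two-atom group for another, which adds a hydrogen-bond acceptor, does not separate the two compounds. Within the data shown here, the fluorine could be read on its own for the first time: fluoro in place of hydrogen on an aromatic carbon gave a 1.3-fold lower number from compound 1 to compound 4 (0.11 log units; within the scatter), which also stays inside the scatter, so with the methoxyphenyl in place this fluorine shows no measurable effect on the number. Among these compounds, the exchange of 2,4-dimethylphenyl for 4-methoxyphenyl gave a 2.0-fold lower number from compound 2 to compound 4 (0.31 log units; beyond the scatter), the first step to pass beyond the scatter, though only modestly, and the only one here that separates two compounds.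

On these data alone, whether an amine, a carboxylic acid or a longer chain such as butyl on this aromatic carbon would move the number further than these small groups have remains open. What lies behind any of these steps also stays open, since nothing available here speaks to a reason for them.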